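Two Oxazoline Ethers, One Nitro-to-Fluoro Swap, One Prediction

The source may report more compounds than this note shows. Statements on the series, on what has been measured and on what is new or still open speak of the compounds shown alone.

Measured compounds:
Compound 1, `Fc1ccc(OCC2=NCCO2)cc1`: 25%
Compound 2, `O=[N+]([O-])c1ccccc1OCC1=NCCO1`: 25%
Compound 3, `O=[N+]([O-])c1ccc(OCC2=NCCO2)cc1`: 15%

Three compounds sharing the same core were run in a toxicity assay on the whole organism with Rattus norvegicus as the target, at a dose of 200 mg/kg by the oral route; a higher number here means a stronger effect of the compound at the dose given, a lower number a weaker effect. Compound 1 gives 25% in this assay, compound 2 gives 25% and compound 3 gives 15%. The values of compound 1 and compound 2 are level at the digits reported, and the value of compound 3 sits within the usual scatter of both.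

Compound 1 and compound 3 are joined by a single change, (fluoro in place of nitro on an aromatic carbon), which produced a step of a number 10 percentage points higher from compound 3 to compound 1 (within the scatter). The difference between the cores of compound 2 and compound 3 is not broken down here.

The unmeasured compound 4, `Fc1ccccc1OCC1=NCCO1`, arises from compound 2 by the same kind of change, (fluoro in place of nitro on an aromatic carbon). It is the same kind of change rather than the same one, as the place differs: in the pair of compound 3 and compound 1 the change sits para to a group of 7 heavy atoms, whereas in the pair of compound 2 and compound 4 it sits ortho to a group of 7 heavy atoms.

For compound 4 a step of a number 5 percentage points higher from compound 2 to compound 4 (within the scatter) is expected in this assay, beside the earlier step, because a number 10 percentage points higher from compound 3 to compound 1 (within the scatter) lay within the scatter. Compound 4 is therefore estimated at 30% in this assay, with a likely range from 15% to 45%.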

Compound 4, a percentage reported as activity, at one dose (the size of the read-out at that dose, not a potency): 15%
For compound 4 the middle estimate is 15 percentage points above the measured one; the range from low to high includes it.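

With fluoro entering where nitro leaves, on an aromatic carbon ortho to a group of 7 heavy atoms, the result in this assay is a number 10 percentage points lower from compound 2 to compound 4 (within the scatter). Set beside the earlier step, this shows that the change does not carry from one core to the other as a fixed step: the same change on two cores in this assay, a number 10 percentage points higher (within the scatter) from compound 3 to compound 1 and a number 10 percentage points lower (within the scatter) from compound 2 to compound 4, 20 percentage points apart, beyond the scatter of two such steps. Within the data shown here, it does not show that the change alone moves the read-out on either core, since each step taken singly lies within the scatter, and with only two pairs, which differ both in core and in where the change sits, the data cannot tell whether that place or some other feature of the core accounts for the gap.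

The compounds shown leave open how the read-out would stand with other groups on the same aromatic carbon, such as chloro, methoxy, an amine or a carboxylic acid, and whether any of these would follow one pattern across both cores. They also leave open whether a third core would side with either pair, so the two steps shown give no general rule for this swap across the series.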